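Bromophenyl isomer: from compound 3 to compound 4

A few compounds are considered here, and "the series" means these few. Any claim that something is new, unique, unknown or untested is made for them only; others in the source may bear on it.

In a functional assay on A549 cells (Homo sapiens) for inhibition, read by MTT assay, with a stated time of 24 h (on this read-out lower numbers stand for stronger inhibition and higher numbers for weaker inhibition), compound 3 (`CC1(C)[C@H]2CC[C@]1(C)N(Cc1cn(-c3ccc(Br)cc3)nn1)C(=O)C2`) gives 80 nM and lies within the scatter of the two other measured compounds. Compound 1 (`CC1(C)[C@H]2CC[C@]1(C)N(Cc1cn(-c3ccccc3Cl)nn1)C(=O)C2`) gives 70 nM and compound 2 (`CC1(C)[C@H]2CC[C@]1(C)N(Cc1cn(-c3ccc(O)cc3)nn1)C(=O)C2`) gives 140 nM on the same read-out. Compound 4 (`CC1(C)[C@H]2CC[C@]1(C)N(Cc1cn(-c3cccc(Br)c3)nn1)C(=O)C2`) has 3-bromophenyl in place of 4-bromophenyl on an aromatic nitrogen. Among the measured compounds shown here, no measured pair isolates this change. Bearing on it are a 1.1-fold higher number from compound 1 to compound 3 (0.06 log units; within the scatter) and a 1.8-fold lower number from compound 2 to compound 3 (0.24 log units; within the scatter) and a 2.0-fold higher number from compound 1 to compound 2 (0.30 log units; within the scatter) with all three within the scatter. A step beyond the scatter is therefore not expected in this assay here. The expected step is small (a 1.1-fold higher number from compound 3 to compound 4 (0.03 log units; within the scatter)). For compound 4 the estimated value is 85 nM with an expected range from 40 nM to 180 nM on this read-out.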

Compound 4, half-maximal inhibitory concentration: 90 nM
Compound 4: middle estimate off by 1.1-fold (0.02 log units), on the low side, within the range that was stated.
By their numbers in this assay, from the lowest: compounds 1, 3, 4 and 2 (each within the scatter of the next).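

In this assay, among the compounds shown here, the isomer pair gives the first direct reading of where the bromo sits on this phenyl ring (a 1.1-fold higher number from compound 3 to compound 4 (0.05 log units; within the scatter)), and 3-bromophenyl cannot be told apart from 4-bromophenyl. The other two new steps (a 1.6-fold lower number from compound 2 to compound 4 (0.19 log units; within the scatter); a 1.3-fold higher number from compound 1 to compound 4 (0.11 log units; within the scatter)) also stay within the scatter, so all four aryl groups on this aromatic nitrogen remain indistinguishable on this read-out. No supporting data explain this flat result. Still open, from the compounds shown here alone, is whether an amine or a carboxylic acid on the phenyl ring, or a longer chain in its place, would give a step beyond the scatter.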